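A few compounds are considered here, and "the series" means these few. Any claim that something is new, unique, unknown or untested is made for them only; others in the source may bear on it.

Three compounds built on a shared core were tested in a functional assay on the whole organism (artery, strain albino) with Rattus norvegicus as the target, with a stated time of 30 min, at a dose of 10 mg/kg by the oral route; on this read-out higher numbers stand for more inhibition at the one dose given (going by the name of the read-out) and lower numbers for less inhibition. Compound 1 `CC1=C(C(=O)Nc2ccc(Br)cc2)C(c2ccc(Cl)cc2Cl)N=C(SCc2ccc(Cl)cc2)N1` gives 6.7% in this assay, and compound 2 `CC1=C(C(=O)Nc2ccc(Br)cc2)C(c2ccc(Cl)cc2Cl)N=C(SCc2ccc(F)cc2)N1` gives 7.7%. The only difference between them is fluoro in place of chloro on an aromatic carbon, and this change produced a number 1 percentage points higher from compound 1 to compound 2 (within the scatter). Compound 3 `CC1=C(C(=O)Nc2ccc([N+](=O)[O-])cc2)C(c2cccc([N+](=O)[O-])c2)N=C(SCc2ccc(Cl)cc2)N1` gives 3.1% in this assay; the difference between its core and the core of compound 1 is not broken down here, and the two values lie within the scatter of each other. Compound 4 `CC1=C(C(=O)Nc2ccc([N+](=O)[O-])cc2)C(c2cccc([N+](=O)[O-])c2)N=C(SCc2ccc(F)cc2)N1` differs from compound 3 by fluoro in place of chloro on an aromatic carbon, the same change that was made from compound 1 to compound 2 at the same place. Because that earlier change gave a number 1 percentage points higher from compound 1 to compound 2 (within the scatter), the step from compound 3 to compound 4 is expected to be a number 0.9 percentage points higher from compound 3 to compound 4 (within the scatter). Compound 4 is therefore estimated at 4%, most likely between 0% and 12%.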

Compound 4, a percentage reported as inhibition, in the whole organism at one dose (the size of the read-out at that dose, not a potency): 4.1%
Compound 4: middle estimate off by 0.1 percentage points, on the low side; measured number inside the range.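

In this assay, putting 4-fluorobenzyl in place of 4-chlorobenzyl gave a number 1 percentage points higher from compound 3 to compound 4 (within the scatter), and the step matched the earlier one on the other core: the same change on two cores in this assay, a number 1 percentage points higher (within the scatter) from compound 1 to compound 2 and a number 1 percentage points higher (within the scatter) from compound 3 to compound 4, 0 percentage points apart, within the scatter of two such steps

The change therefore carried from one core to the other without any visible difference in size. As each step lies within the scatter, this agreement does not show that the change has a real effect on either core, and it says nothing about cores beyond these two.

All four compounds carry a halogen at this place, which leaves open what an amine or a carboxylic acid there would give. From the compounds shown here alone, a longer chain in place of the benzyl group also remains open.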